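This account rests on a few compounds, and the source may have more. Where it says the series, first, only, none or still open, it means among the compounds named here.

Compound 1 `CC(C)(C)OC(=O)N1CCN(C(=S)SCc2cn(-c3ccccc3F)nn2)CC1` is the point of departure. In a functional assay on ECa-109 cells (Homo sapiens) for inhibition, read by MTT assay, with a stated time of 72 h (a lower number here means a stronger inhibitor, a higher number a weaker inhibitor), compound 1 gives only a limit, > 128000 nM, and so stands at the limit of > 128000 nM in this assay, at which 1 of the 3 values shown sits. Compound 2 `O=C(OCc1ccccc1)N1CCN(C(=S)SCc2cn(Cc3ccc(F)cc3)nn2)CC1` gives 32000 nM in this assay, and compound 3 `O=C(OCc1ccccc1)N1CCN(C(=S)SCc2cn(Cc3ccc(Cl)c(Cl)c3)nn2)CC1` gives 29400 nM; the step of a 1.1-fold lower number from compound 2 to compound 3 (0.04 log units; within the scatter) shows that exchanging the aryl part of such a benzyl group changes little. Compound 4 `Cc1ccc(Cn2cc(CSC(=S)N3CCN(C(=O)OC(C)(C)C)CC3)nn2)cc1` differs from compound 1 by 4-methylbenzyl in place of 2-fluorophenyl on an aromatic nitrogen. For the measured compounds named here, no measured step covers this change directly, so the expectation rests on compounds 2 and 3 having a measurable number with a benzyl group on the triazole nitrogen. Compound 4 is therefore expected to fall into the measurable range at about 45000 nM, between 15000 nM and 140000 nM, a step estimated as an at least 2.8-fold lower number from compound 1 to compound 4 (0.45 log units; beyond the scatter).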

Compound 4, half-maximal inhibitory concentration: 47900 nM
The estimate for compound 4 lay 1.1-fold (0.03 log units) below the measured number, and the stated range covers the measured number.
By their numbers in this assay, from the lowest: compounds 3, 2 and 4 (each within the scatter of the next). At a limit, above all of these: compound 1.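

Putting 4-methylbenzyl in place of 2-fluorophenyl on the aromatic nitrogen gives an at least 2.6-fold lower number from compound 1 to compound 4 (0.42 log units; beyond the scatter), so this change brings the core of compound 1 to a measurable number in this assay. Compound 1 itself gives only a limit: the limit of > 128000 nM in this assay, at which 1 of the 4 values shown sits. The step is therefore a lower bound, and this single pair cannot separate the loss of fluorine from the gain of the chain carbon or the methyl group.

As far as these compounds go, it remains open how a longer chain in this place, such as 2-phenylethyl, or an amine on the aromatic ring would read in this assay.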